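Removing the 3,5-difluorophenyl of compound 1

This account rests on a few compounds, and the source may have more. Where it says the series, first, only, none or still open, it means among the compounds named here.

Compound 1 `O=C1O[C@H]([C@@H](O)Cn2cc(-c3cc(F)cc(F)c3)nn2)C(OCc2ccccc2)=C1OCc1ccccc1`: 48200 nM
Compound 2 `O=C1O/C(=C\Cn2cc(-c3ccc(Br)cc3)nn2)C(OCc2ccccc2)=C1OCc1ccccc1`: > 100000 nM, a limit
Compound 3 `CC(C)(C)OC(=O)N1CCN(C(=S)SCc2cn(C[C@H](O)[C@H]3OC(=O)C(OCc4ccccc4)=C3OCc3ccccc3)nn2)CC1`: > 100000 nM, a limit

Going by the values given here, in a functional assay on HCT-116 cells (Homo sapiens) for antiproliferative activity, read by MTT assay, with a stated time of 72 h (on this read-out lower numbers stand for stronger inhibition and higher numbers for weaker inhibition), compound 1 gives 48200 nM, the only number among the three values shown. For compound 2 this assay reports only a limit, > 100000 nM. For compound 3 it likewise reports only a limit, > 100000 nM. Among the compounds with values here, what stands out is the limit of > 100000 nM in this assay, at which 2 of the 3 values shown sit, so compound 1 is the single measured value. Compound 4 `O=C1O[C@H]([C@@H](O)Cn2ccnn2)C(OCc2ccccc2)=C1OCc1ccccc1` is not yet measured; it differs from compound 1 by hydrogen in place of 3,5-difluorophenyl on an aromatic carbon. Within the data shown here, no step between measured compounds is available to calibrate this change. The expected step of a 2.1-fold higher number from compound 1 to compound 4 (0.32 log units; beyond the scatter) in this assay goes toward weaker inhibition, beyond the scatter. Compound 4 is estimated at 100000 nM, within 30000 nM to 300000 nM, with a fair chance that this assay returns only a limit.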

Compound 4, half-maximal inhibitory concentration: > 100000 nM
Compound 4: only a limit was reported; the forecaster's own chance of this, stated with the estimate: 55%; the middle value lies on the limit itself.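

Replacing the 3,5-difluorophenyl with hydrogen on this aromatic carbon gives an at least 2.0-fold higher number from compound 1 to compound 4 (0.31 log units; beyond the scatter) in this assay, so for this pair the measurable activity goes with the aryl group being present. Compound 4 gives > 100000 nM, which is a limit and not a number. The step is therefore only a bound, because compound 4 stands at that limit: the limit of > 100000 nM in this assay, at which 3 of the 4 values shown sit.

The compounds shown leave open whether the two fluorines matter, or only the ring that carries them. A plain phenyl, a methyl or an aminomethyl on the same aromatic carbon could separate these possibilities.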